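Stereochemistry of a bicyclic thiadiazole in a rat inhibition assay

The source may hold more compounds than are shown below. What is called first, only, known or untested is meant among the compounds shown, and "the series" means these compounds.

Measured so far:
compound 1 `CCCCSc1nsnc1[C@H]1CN2CCC[C@H]1C2`, > 3 mg/kg in a functional assay on the whole organism for inhibition, with Rattus norvegicus as the target; a lower number here means that less compound is needed, a higher number that more compound is needed for the effect
compound 2 `CCCCSc1nsnc1[C@@H]1CN2CCC[C@@H]1C2`, > 3 mg/kg
compound 3 `CCCCSc1nsnc1C1CN2CCC[C@H]1C2`, 0.007 mg/kg

Compound 1 gives only a limit of this assay, > 3 mg/kg. Compound 2 likewise reaches only a limit, > 3 mg/kg. Within the data shown here, compound 3 is the one compound with a number, and it sits far from both limits: the step of an at least 420-fold lower number from compound 1 to compound 3 (2.63 log units; beyond the scatter) and the step of an at least 420-fold lower number from compound 2 to compound 3 (2.63 log units; beyond the scatter) are both large and beyond the scatter. The step that the two limits leave unreadable from compound 1 to compound 2 cannot be read, because the limit of > 3 mg/kg in this assay, at which 2 of the 3 values shown sit, holds both ends.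

Compound 4 `CCCCSc1nsnc1[C@H]1CN2CCC[C@@H]1C2` has the same atoms and bonds as compound 3; the change is the two compounds have the same atoms and bonds; at least one stereo element is drawn with a configuration in one of them and without one in the other: 2 of 3 stereo elements differ; a stereocentre at a saturated ring carbon is drawn without a configuration in compound 3 and R in compound 4; a stereocentre at a saturated ring carbon is drawn R in compound 3 and S in compound 4. Both measured steps that bear on a change of drawn configuration alone, from compound 1 to compound 3 and from compound 2 to compound 3, were large, so a large step in this assay is plausible here as well. Which direction it takes for compound 4 is not settled by the shown values; compound 3, drawn without configuration at one centre, covers more than one arrangement, and compound 4 fixes both.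

Compound 4 is expected to give 0.3 mg/kg, within 0.01 mg/kg to 3 mg/kg, a step of a 43-fold higher number from compound 3 to compound 4 (1.63 log units; beyond the scatter).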

Compound 4, dose for half-maximal effect: 0.017 mg/kg
For compound 4 the middle estimate is 18-fold (1.25 log units) above the measured one; the measured number falls inside the stated range.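

In this assay, among these compounds, compound 4 is the one compound with both ring-carbon stereocentres drawn that gives a number rather than a limit, so a fully defined arrangement can carry the effect. A single stereocentre at a saturated ring carbon separates it from each of the two compounds held at a limit, and both of the following steps start from such a limit: an at least 170-fold lower number from compound 1 to compound 4 (2.24 log units; beyond the scatter) and an at least 170-fold lower number from compound 2 to compound 4 (2.24 log units; beyond the scatter). Fixing the undrawn centre as R and drawing the other centre as S instead of R costs far less, a 2.4-fold higher number from compound 3 to compound 4 (0.39 log units; beyond the scatter), a modest step though one beyond the scatter.

The compounds shown leave open how the remaining arrangement, with the first of these centres drawn S and the second R, would read, and so which arrangement or arrangements account for the number of compound 3. They also leave open whether the same dependence on configuration would hold with a longer chain, or with an amine, in place of the sulfur-bound butyl chain.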